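The source may hold more compounds than are shown below. What is called first, only, known or untested is meant among the compounds shown, and "the series" means these compounds.

Compound 1 `CC(C(=O)O)c1nn(Cc2cn3cc(OCC4CC4)c(Cl)cc3n2)c2ccccc2c1=O`: 31 nM
Compound 2 `O=C(O)Cn1nc(Cn2cc3cc(OCC4CC4)c(Cl)cc3n2)c2ccccc2c1=O`: 53 nM
Compound 3 `CC(C)(C(=O)O)c1nn(Cc2cn3cc(OCC4CC4)c(Cl)cc3n2)c2ccccc2c1=O`: 105 nM

All three were tested in a functional assay on CHO cells for antagonist activity at sphingosine 1-phosphate receptor 2 (Homo sapiens), read by GTPgammaS binding; on this read-out lower numbers stand for stronger inhibition and higher numbers for weaker inhibition. Compound 1 and compound 3 share one core; compound 2 has a different core, and the difference between the two cores is not broken down here. Compound 4 `C[C@H](C(=O)O)n1nc(Cn2cc3cc(OCC4CC4)c(Cl)cc3n2)c2ccccc2c1=O` has not yet been measured. It differs from compound 2 by methyl in place of hydrogen on a saturated chain carbon bound to an aromatic nitrogen and a carbonyl carbon. A change of the same kind, (methyl in place of hydrogen on a saturated chain carbon bound to an aromatic carbon, a carbonyl carbon and a saturated chain carbon), was made from compound 1 to compound 3 and gave a 3.4-fold higher number from compound 1 to compound 3 (0.53 log units; beyond the scatter). The surroundings differ: in compound 1 the carbon is bound to an aromatic carbon, a carbonyl carbon and a saturated chain carbon, in compound 2 to an aromatic nitrogen and a carbonyl carbon. Compound 4 is therefore expected to show a 2.3-fold higher number from compound 2 to compound 4 (0.35 log units; beyond the scatter), a step of roughly similar size, resting on a 3.4-fold higher number from compound 1 to compound 3 (0.53 log units; beyond the scatter). Compound 4 is estimated at 120 nM, between 50 nM and 300 nM.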

Compound 4, half-maximal inhibitory concentration in the sphingosine 1-phosphate receptor 2 assay: 15 nM
The estimate for compound 4 lay 8.0-fold (0.90 log units) above the measured number, outside the stated range (below it).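

In the sphingosine 1-phosphate receptor 2 assay compound 2 gives 53 nM and compound 4 gives 15 nM. In the sphingosine 1-phosphate receptor 2 assay the change from carboxymethyl to 1-carboxyethyl gave a 3.5-fold lower number from compound 2 to compound 4 (0.55 log units; beyond the scatter), so methyl in place of hydrogen went in opposite directions on the two cores: the same change on two cores in the sphingosine 1-phosphate receptor 2 assay, a 3.4-fold higher number (0.53 log units; beyond the scatter) from compound 1 to compound 3 and a 3.5-fold lower number (0.55 log units; beyond the scatter) from compound 2 to compound 4, 12-fold (1.08 log units) apart, beyond the scatter of two such steps

In this series, then, the step seen on one core cannot simply be carried over to the other. Among the compounds shown here, with only one pair on each core, this does not show which difference between the cores lies behind the gap, or whether it would hold for other compounds.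

On these data alone, it remains open how an ethyl group or a longer chain would behave in place of that methyl on either core. In a physicochemical assay for solubility, measured as thermodynamic solubility, at pH 7.4 (a higher number here means a more soluble compound, a lower number a less soluble compound), compound 2 gives 334 ug/mL and compound 4 gives 958 ug/mL. The result in the physicochemical assay, a 2.9-fold higher number from compound 2 to compound 4 (0.46 log units; beyond the scatter), also leaves open whether the core of compound 1 would respond the same way.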